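This account rests on a few compounds, and the source may have more. Where it says the series, first, only, none or still open, it means among the compounds named here.

Measured compounds in an assay on mitochondria from L6 cells (Rattus norvegicus) for activation, with a stated time of 90 min; a lower number here means that less compound is needed, a higher number that more compound is needed for the effect:
- compound 1, `Oc1nc2nonc2nc1Nc1ccc(OCC(F)(F)F)cc1`, gives 42300 nM
- compound 2, `Cc1cc(Nc2nc3nonc3nc2O)ccc1OCC(F)(F)F`, gives 7000 nM
- compound 3, `Oc1nc2nonc2nc1Nc1ccc(OCC(F)(F)F)c(C(F)(F)F)c1`, gives 4000 nM

Compound 1 holds the highest number of the three. Its nearest neighbour is compound 2, reached by a 6.0-fold lower number from compound 1 to compound 2 (0.78 log units; beyond the scatter), and the furthest is compound 3, reached by an 11-fold lower number from compound 1 to compound 3 (1.02 log units; beyond the scatter). Between those two, the step of a 1.8-fold lower number from compound 2 to compound 3 (0.24 log units; within the scatter) stays within the scatter.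

Compound 4, `CCCCCc1ccc(Nc2nc3nonc3nc2O)cc1`, is not yet measured. It differs from compound 1 as follows: pentyl in place of 2,2,2-trifluoroethoxy on an aromatic carbon. Among the measured compounds shown here, none of the measured steps touches the 2,2,2-trifluoroethoxy group itself; both keep it in place and add a group elsewhere on the same ring. They therefore say nothing direct about what pentyl in place of 2,2,2-trifluoroethoxy will do. What they do show is that compound 1, with the group unaltered, sits at the top of the range, so the shared core tolerates changes on this ring without losing the effect. For the measured compounds named here, with no step bearing on the exchange, the expected step of a 1.7-fold lower number from compound 1 to compound 4 (0.23 log units; within the scatter) is uncertain, and a change in either direction that stays within the scatter is the most defensible expectation. Compound 4 is estimated to give 25000 nM, with a range from 6000 nM to 100000 nM.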

Compound 4, half-maximal effective concentration: 2400 nM
Compound 4: the middle estimate sits 10-fold (1.02 log units) above what was measured; measured number below the stated range.
By their numbers in this assay, from the lowest: compounds 4, 3 and 2 (each within the scatter of the next, the first and the last beyond it); then compound 1.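

In this assay, the exchange of 2,2,2-trifluoroethoxy for pentyl, on the aromatic carbon para to a large group, gives a large change (an 18-fold lower number from compound 1 to compound 4 (1.25 log units; beyond the scatter)), and it is the first step shown that alters this position itself. The earlier steps shown here kept the 2,2,2-trifluoroethoxy group and added a group elsewhere on the same ring, whereas this one shows that the group can be removed entirely and that less compound is then needed, with a chain of carbon only that has no oxygen, no fluorine and no hydrogen-bond acceptor. The compounds shown come with no separate measurement that offers a reason for this step.

Because this single exchange replaces the oxygen, the fluorines and the chain together, the compounds shown cannot tell which of these changes accounts for the step. Going by these compounds, it also remains open what a butoxy group, a longer chain such as octyl, an amine or a carboxylic acid would give at this position, and whether adding methyl or trifluoromethyl to the ring of compound 4 would lower the number as it did for compound 1.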